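Bromo for Methyl on the Aryl Ring of Compound 1

The source may report more compounds than this note shows. Statements on the series, on what has been measured and on what is new or still open speak of the compounds shown alone.

Compound 1 `COc1ccc(/C=C2/CN(C)/C(=N/c3ccc(C)cc3)S2)cc1` holds the lowest of the two numbers shown: in a functional assay on MCF7 cells (Homo sapiens) for antiproliferative activity, read by MTT assay, with a stated time of 72 h (on this read-out lower numbers stand for stronger inhibition and higher numbers for weaker inhibition), compound 1 gives 7600 nM. Its nearest neighbour, compound 2 `COc1ccc(/C=C2\S/C(=N\c3ccc(F)cc3)N(C)C2=O)cc1`, gives 66500 nM in this assay, a higher number that lies beyond the scatter. Compound 3 `COc1ccc(/C=C2\S/C(=N\c3c(C)cccc3C)N(C)C2=O)cc1` reaches only a limit of this assay, > 100000 nM, which is a limit rather than a number. That is the limit of > 100000 nM in this assay, at which 1 of the 3 values shown sits. Within the data shown here, the single measured step, an at least 1.5-fold higher number from compound 2 to compound 3 (0.17 log units; that floor lies within the scatter), carries 2,6-dimethylphenyl in place of 4-fluorophenyl on a double-bonded nitrogen, and its floor sits within the scatter.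

Compound 4 `COc1ccc(/C=C2/CN(C)/C(=N/c3ccc(Br)cc3)S2)cc1` differs from compound 1 by bromo in place of methyl on an aromatic carbon. Among the measured compounds shown here, no measured step touches this exchange: the step from compound 2 to compound 3 alters the aryl group in another way and runs into a limit, so it tells nothing about swapping bromo for methyl. Compound 1 is therefore the only anchor, and a change of about a 1.1-fold lower number from compound 1 to compound 4 (0.04 log units; within the scatter) is expected, no larger than the scatter. Compound 4 is estimated at 7000 nM in this assay, with a range from 2500 nM to 20000 nM.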

Compound 4, half-maximal inhibitory concentration: 7400 nM
The estimate for compound 4 lay 1.1-fold (0.02 log units) below the measured number; low and high end bracket the measured number.
By their numbers in this assay, from the lowest: compounds 4 and 1 (each within the scatter of the next); then compound 2. At a limit, above all of these: compound 3.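

In this assay, bromo in place of methyl on an aromatic carbon gives a 1.0-fold lower number from compound 1 to compound 4 (0.01 log units; within the scatter), so the 4-methylphenyl and 4-bromophenyl forms of this core cannot be told apart on this read-out. This is the first step shown at this position on the core of compound 1; the only earlier step changed the aryl group in another way, on a different core, and ended at a limit, so it could say nothing about this exchange. The position therefore accepts a bromine atom in place of the methyl carbon with no change beyond the scatter, although nothing shown here bears on why the two groups read alike.

What the compounds shown leave open is whether this position stays as undemanding for a group of another kind, such as an amine, a carboxylic acid or a longer chain, in place of methyl or bromo. They also leave open whether the exchange of methyl for bromo would read the same way on the core of compound 2, which carries a carbonyl.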